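Trading 4-chlorophenyl for a Butyl Chain

This account rests on a few compounds, and the source may have more. Where it says the series, first, only, none or still open, it means among the compounds named here.

Compound 2 (`C=C1C(=O)[C@@]23C(=O)OC[C@]4([C@@H](OC(C)=O)CCC(C)(C)[C@H]4C=O)[C@@H]2CC[C@H]1[C@H]3OC(=O)c1ccc(Cl)cc1`) gives 870 nM in a functional assay on K562 cells (Homo sapiens) for inhibition, read by MTT assay (on this read-out lower numbers stand for stronger inhibition and higher numbers for weaker inhibition), and stands within the scatter of both relatives: compound 1 (`C=C1C(=O)[C@@]23C(=O)OC[C@]4([C@@H](OC(C)=O)CCC(C)(C)[C@H]4C=O)[C@@H]2CC[C@H]1[C@H]3OC(=O)CC`) gives 1500 nM and compound 3 (`C=C1C(=O)[C@@]23C(=O)OC[C@]4([C@@H](OC(C)=O)CCC(C)(C)[C@H]4C=O)[C@@H]2CC[C@H]1[C@H]3OC(=O)c1ccc([N+](=O)[O-])cc1`) gives 1140 nM on that read-out. Compound 4 (`C=C1C(=O)[C@@]23C(=O)OC[C@]4([C@@H](OC(C)=O)CCC(C)(C)[C@H]4C=O)[C@@H]2CC[C@H]1[C@H]3OC(=O)CCCC`) carries butyl in place of 4-chlorophenyl on a carbonyl carbon. Going by the values given here, two measured steps bear on this change: ethyl to 4-chlorophenyl (a 1.7-fold lower number from compound 1 to compound 2 (0.24 log units; within the scatter)) and ethyl to 4-nitrophenyl (a 1.3-fold lower number from compound 1 to compound 3 (0.12 log units; within the scatter)). Both stayed within the scatter, and neither tests butyl itself. Compound 4 returns to an open chain, as in compound 1 at 1500 nM on this read-out, so only a slight rise is expected in this assay and nothing beyond the scatter. The expected outcome is a 1.4-fold higher number from compound 2 to compound 4 (0.14 log units; within the scatter) overall. Compound 4 is estimated at 1200 nM with 700 nM to 2100 nM as its expected range.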

Compound 4, half-maximal inhibitory concentration: 1560 nM
Estimate against measurement, compound 4: 1.3-fold (0.11 log units) below; measured number inside the range.
By their numbers in this assay, from the lowest: compounds 2, 3, 1 and 4 (each within the scatter of the next).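

In this assay, the step from an aromatic ring to an open chain gives a 1.8-fold higher number from compound 2 to compound 4 (0.25 log units; within the scatter) and a 1.4-fold higher number from compound 3 to compound 4 (0.14 log units; within the scatter) as well, so on this carbonyl carbon neither ring-bearing group stands apart from butyl. Extending the open chain from ethyl to butyl gives a 1.0-fold higher number from compound 1 to compound 4 (0.02 log units; within the scatter) and shows that, among these four compounds, chain length up to butyl makes no measurable difference here. Nothing available explains why these groups read alike. From the compounds shown here alone, whether an amine, a carboxylic acid or a chain longer than butyl at this place would move the number beyond the scatter remains open.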